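The source may report more compounds than this note shows. Statements on the series, on what has been measured and on what is new or still open speak of the compounds shown alone.

In a functional assay on MCF7 cells (Homo sapiens) for antiproliferative activity, read by MTT assay, with a stated time of 48 h (on this read-out lower numbers stand for stronger inhibition and higher numbers for weaker inhibition), compound 1 `Fc1ccc(NCc2cn(-c3ccccc3)nc2-c2ccc(Cl)cc2)cc1` gives 1880 nM, compound 2 `Cc1ccc(NCc2cn(-c3ccccc3)nc2-c2ccc(C)cc2)cc1` gives 7260 nM and compound 3 `COc1ccc(-c2nn(-c3ccccc3)cc2CNc2ccc(F)cc2)cc1` gives 5980 nM. Compound 3 therefore sits with compound 2 at the weaker end of these three numbers, the two lying within the scatter of each other, while compound 1 stands clearly lower.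

Compound 4 `Cc1ccc(-c2nn(-c3ccccc3)cc2CNc2ccc(F)cc2)cc1` differs from compound 3 in one place: methyl in place of methoxy on an aromatic carbon, para to a large group. Among the compounds with values here, no measured step makes exactly this swap. The nearest is a 3.2-fold higher number from compound 1 to compound 3 (0.50 log units; beyond the scatter), a modest step with methoxy in place of chloro on an aromatic carbon, and it says nothing directly about methyl. Compound 2 also carries the 4-methylphenyl group but differs elsewhere too, and its 7260 nM lies within the scatter of the number for compound 3.

In this assay, no step beyond the scatter is therefore expected, and the estimated change is a 1.1-fold lower number from compound 3 to compound 4 (0.04 log units; within the scatter). For compound 4 the estimated value is 5500 nM, with an expected range of 2600 nM to 11000 nM.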

Compound 4, half-maximal inhibitory concentration: 5880 nM
Estimate against measurement, compound 4: 1.1-fold (0.03 log units) below, and the stated range covers the measured number.
By their numbers in this assay, from the lowest: compound 1; then compounds 4, 3 and 2 (each within the scatter of the next).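

In this assay, swapping 4-methoxyphenyl for 4-methylphenyl changes the number by no more than the scatter (a 1.0-fold lower number from compound 3 to compound 4 (0.01 log units; within the scatter)), so methoxy and methyl cannot be told apart at this place, while chloro stays apart from methyl as it did from methoxy (a 3.1-fold higher number from compound 1 to compound 4 (0.50 log units; beyond the scatter)). With the 4-methylphenyl group kept, fluoro in place of methyl at the other changed place on an aromatic carbon also stays within the scatter (a 1.2-fold lower number from compound 2 to compound 4 (0.09 log units; within the scatter)). On these data alone, whether a larger group here, such as a longer chain like butoxy, would stay with methoxy and methyl or move towards chloro remains open. So does the effect of an amine or a carboxylic acid on this carbon. Nothing available explains why chloro stands apart.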